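The source may hold more compounds than are shown below. What is called first, only, known or untested is meant among the compounds shown, and "the series" means these compounds.

Measured so far:
compound 1, `CN(c1ccn(C)n1)c1cnc(NCc2c(F)ccc3c2CCO3)c2cn[nH]c(=O)c12`: 2.4
compound 2, `CN(C)C(=O)c1cc(-c2cnc(NCc3c(F)ccc4c3CCO4)c3cn[nH]c(=O)c23)n(C)n1`: 2.1
compound 3, `CNC(=O)c1ccc(-c2cnc(NCc3c(F)ccc4c3CCO4)c3cn[nH]c(=O)c23)c(C)n1`: 2.9

In a physicochemical assay for lipophilicity, using the shake flask method, in phosphate buffer, measured as octanol-water partition, with a stated time of 30 min, at pH 7.4 (a lower number here means a more polar compound, a higher number a more lipophilic compound), compound 3 stands highest of the three. Its nearest neighbour is compound 1, with a number 0.50 log units higher from compound 1 to compound 3 (beyond the scatter), and its furthest is compound 2, with a number 0.80 log units higher from compound 2 to compound 3 (beyond the scatter). Compound 1 and compound 2 are separated only by a number 0.30 log units lower from compound 1 to compound 2 (within the scatter).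

Compound 4, `CNC(=O)c1ncc(-c2cnc(NCc3c(F)ccc4c3CCO4)c3cn[nH]c(=O)c23)n1C`, has not yet been measured in this assay. It differs from compound 3 in one place: 1-methyl-2-(methylcarbamoyl)-1H-imidazol-5-yl in place of 2-methyl-6-(methylcarbamoyl)pyridin-3-yl on an aromatic carbon

Among the compounds with values here, the most relevant measured step is the one from compound 2 to compound 3, where a five-membered aromatic ring carrying a carbamoyl group stood in place of the six-membered one, and this assay rose modestly. The change from compound 3 to compound 4 goes the other way, back to a five-membered ring with two hetero atoms and one more hydrogen-bond acceptor, so a modest drop beyond the scatter is expected, of about a number 0.60 log units lower from compound 3 to compound 4 (beyond the scatter). Compound 4 is therefore estimated at 2.3, with a range from 1.8 to 2.8.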

Compound 4, distribution coefficient: 2.5
Beside the measured number, compound 4's estimate is 0.20 log units below it, and the stated range covers the measured number.
By their numbers in this assay, from the lowest: compounds 2, 1 and 4 (each within the scatter of the next, the first and the last beyond it); then compound 3.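

Within the measured set, the change at this aromatic carbon from the 2-methyl-6-(methylcarbamoyl)pyridin-3-yl group to the 1-methyl-2-(methylcarbamoyl)-1H-imidazol-5-yl group gives a number 0.40 log units lower from compound 3 to compound 4 (beyond the scatter) in this assay and shows that the methylcarbamoyl-bearing six-membered ring is not the only group that separates from compound 2. The two five-membered aromatic rings also read apart, with a number 0.40 log units higher from compound 2 to compound 4 (beyond the scatter) for the imidazolyl group in place of the 3-(dimethylcarbamoyl)-1-methyl-1H-pyrazol-5-yl group, whereas a number 0.10 log units higher from compound 1 to compound 4 (within the scatter) leaves the imidazolyl group and the methyl(1-methyl-1H-pyrazol-3-yl)amino group level within the scatter, so a carbamoyl-bearing ring at this position does not by itself set the reading. Nothing available here accounts for these differences.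

Compound 2 and compound 4 differ in both the ring and the amide, so the compounds shown do not separate the effect of the ring from that of the dimethylcarbamoyl and methylcarbamoyl groups. As far as these compounds go, how a primary carboxamide, a carboxylic acid or an amine on the imidazole ring would read at this position also remains open.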